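Furan replaces fluorophenyl on the ketone arm of the hydroxamate series

This account rests on a few compounds, and the source may have more. Where it says the series, first, only, none or still open, it means among the compounds named here.

The series is tested in an assay on isolated protein for inhibition of histone deacetylase HD1B (Zea mays); on this read-out lower numbers stand for stronger inhibition and higher numbers for weaker inhibition. Compound 1 `Cn1cc(/C=C/C(=O)c2ccc(Cl)cc2)cc1/C=C/C(=O)NO` gives 29400 nM. Compound 2 `Cn1cc(/C=C/C(=O)c2ccc(F)cc2)cc1/C=C/C(=O)NO` gives 24900 nM. Among the compounds with values here, the only step measured so far, fluoro in place of chloro on an aromatic carbon, gives a 1.2-fold lower number from compound 1 to compound 2 (0.07 log units; within the scatter). Compound 2 therefore stands at the lowest of the two numbers, but its distance to compound 1 lies within the scatter, so no order between the two is claimed.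

Compound 3 `Cn1cc(/C=C/C(=O)c2ccco2)cc1/C=C/C(=O)NO` is not yet measured. It differs from compound 2 by furan-2-yl in place of 4-fluorophenyl on a carbonyl carbon. Within the data shown here, no measured step touches the ring that sits on the carbonyl carbon; the one known step concerns only the halogen on that ring and was within the scatter. There is thus no basis for expecting a change beyond the scatter in this assay, and the step from compound 2 to compound 3 is estimated at a 1.2-fold higher number from compound 2 to compound 3 (0.08 log units; within the scatter). Compound 3 is expected to give about 30000 nM, with a range from 10000 nM to 90000 nM.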

Compound 3, half-maximal inhibitory concentration: 19700 nM
Compound 3: middle estimate off by 1.5-fold (0.18 log units), on the high side, and the stated range covers the measured number.
By their numbers in this assay, from the lowest: compounds 3, 2 and 1 (each within the scatter of the next).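

In this assay, the ring on the carbonyl carbon itself can be exchanged, not only the halogen on it: furan-2-yl in place of 4-fluorophenyl gives a 1.3-fold lower number from compound 2 to compound 3 (0.10 log units; within the scatter), and furan-2-yl in place of 4-chlorophenyl gives a 1.5-fold lower number from compound 1 to compound 3 (0.17 log units; within the scatter). At this place, then, the five-membered aromatic ring with its hydrogen-bond acceptor and the six-membered aromatic rings of carbon are not told apart, and the halogen-bearing phenyl rings are no requirement for the level seen in this series. No supporting data are available that bear on this result.

As far as these compounds go, whether an amine, a carboxylic acid or a longer chain on the carbonyl carbon would give a step beyond the scatter remains open. From the compounds shown here alone, the effect of changes to the shared core or to the hydroxamic acid arm also remains open.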